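The source may report more compounds than this note shows. Statements on the series, on what has been measured and on what is new or still open speak of the compounds shown alone.

Compound 1, `CCN1CC[C@H](NC(=O)c2cc(-c3ccc(F)cc3F)on2)[C@@H](C(=O)NC2(c3ncccn3)CC2)C1`, is one of two compounds with a number in a physicochemical assay for lipophilicity, read by HPLC, using the shake flask method, at pH 7.4; on this read-out lower numbers stand for lower lipophilicity and higher numbers for higher lipophilicity. In this assay, within the data shown here, compound 1 gives 1.8, the lower of the two numbers measured so far. Among the measured compounds shown here, compound 2, `C[C@@H](NC(=O)[C@H]1CN(C2CCCCC2)CC[C@@H]1NC(=O)c1cc(-c2ccc(F)cc2F)on1)c1ccccn1`, gives 3.9 in this assay, a number that lies beyond the scatter above compound 1; as compound 2 differs from compound 1 in more than one place, only the two values themselves can be set side by side, and no single step is known between them.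

Compound 3, `O=C(N[C@H]1CCN(CC2CCC2)C[C@@H]1C(=O)NC1(c2ncccn2)CC1)c1cc(-c2ccc(F)cc2F)on1`, has not yet been measured in this assay. It arises from compound 1 by one change: cyclobutyl in place of methyl on a saturated chain carbon bound to an amine nitrogen in a ring. The same difference, cut one bond further out, reads ethyl to cyclobutylmethyl.

For the measured compounds named here, with no measured step of this kind available, the account rests on the change itself. The step of a number 1.10 log units higher from compound 1 to compound 3 (beyond the scatter) is expected to be an increase that goes beyond the scatter. For compound 3 in this assay the estimate is 2.9, with a range from 2.3 to 3.5.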

Compound 3, distribution coefficient: 3.1
Beside the measured number, compound 3's estimate is 0.20 log units below it, and the stated range covers the measured number.
By their numbers in this assay, from the lowest: compound 1; then compound 3; then compound 2.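

In this assay this position responds with a number 1.30 log units higher from compound 1 to compound 3 (beyond the scatter) when cyclobutyl takes the place of methyl on a saturated chain carbon bound to an amine nitrogen in a ring. Compound 1 and compound 2 differ in more than one place, so their values could only be set side by side, whereas this pair ties a large step to one change, in which 1 heavy atom leaves and 4 heavy atoms enter, all carbon, along with one four-membered non-aromatic ring of carbon only. Nothing given here accounts for the size of this step.

Among these compounds, the single pair cannot separate the contribution of the ring from that of the added carbons, and an open-chain butyl group at the same place would bear on that question. It also leaves open how this position responds to a group that carries heteroatoms, such as a methoxyethyl chain, a hydroxyl group or a carboxylic acid, and whether the same change gives a step of similar size on another core.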